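The source may hold more compounds than are shown below. What is called first, only, known or untested is meant among the compounds shown, and "the series" means these compounds.

Of the compounds shown here, three have been measured in an assay on HEK293 cells for positive allosteric modulation of metabotropic glutamate receptor 2 (Rattus norvegicus), read by thallium flux, with a stated time of 2.5 min; a lower number here means a smaller maximal response, a higher number a larger maximal response. Compound 1 `COc1cc(C(=O)O)ccc1OCCCCOc1ccc(C(=O)CC(C)C)c(O)c1C` gives 85.7% in this assay. Compound 2 `Cc1c(OCCCCOc2ccc(C(=O)O)cc2)ccc(C(=O)CC2CCCC2)c1C` gives 16.2% in this assay, and compound 3 `Cc1c(OCCCCOc2ccc(C(=O)O)cc2)ccc(C(=O)CC(C)C)c1C` gives 19% in this assay. Compound 3 therefore stands second highest of the three numbers: its nearest neighbour is compound 2, within the scatter, and its furthest is compound 1, beyond the scatter.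

Compound 4 `Cc1c(OCCCCOc2cccc(C(=O)O)c2)ccc(C(=O)CC(C)C)c1C` has not yet been measured. It differs from compound 3 by 3-carboxyphenyl in place of 4-carboxyphenyl on an oxygen on a saturated carbon, so the two have the same atoms, joined differently. For the measured compounds named here, the only step measured so far, a number 2.8 percentage points higher from compound 2 to compound 3 (within the scatter), concerns a change on the saturated chain carbon bound to the carbonyl carbon and does not touch the carboxyphenyl group, so it tells little about the present change. Going by the values given here, no measured pair shows what moving the carboxylic acid on that ring does. Among the compounds with values here, compound 3 and compound 2 sit close together, and compound 1 stands far above both, but compound 1 differs from compound 3 in more than one place, so no step is drawn between them.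

With nothing directly bearing on this change, a step of no clear direction is expected, roughly within the scatter, as a number 3 percentage points higher from compound 3 to compound 4 (within the scatter). Compound 4 is estimated to give 22% in this assay, expected to lie between 6% and 48%.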

Compound 4, largest response reached (reported as percent of maximum), in percent of the reference or control that the assay uses: 12.1%
Compound 4: the middle estimate sits 9.9 percentage points above what was measured, and the stated range covers the measured number.
By their numbers in this assay, from the lowest: compounds 4, 2 and 3 (each within the scatter of the next); then compound 1.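

Moving the acid, with 3-carboxyphenyl in place of 4-carboxyphenyl on an oxygen on a saturated carbon, gives the first reading at this position: in this assay the step is a number 6.9 percentage points lower from compound 3 to compound 4 (within the scatter). For this pair, which has the same atoms joined differently, the two placements of the carboxylic acid on the ring therefore cannot be told apart in maximal response. Nothing available offers an explanation for this result.

The compounds shown leave open what an amide or a sulfonic acid in place of the carboxylic acid on this ring would give, or what a longer chain between the two oxygens would do. Going by these compounds, compound 1 differs from compound 3 in more than one place, so which of those differences goes with its number also remains open.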